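Ortho substituent on the hydrazone aryl ring

This account rests on a few compounds, and the source may have more. Where it says the series, first, only, none or still open, it means among the compounds named here.

The series shares the core of compound 1 `Cc1c(C(=O)N/N=C\c2ccccc2F)oc2cccc(O)c12`. In a functional assay on PC-3 cells (Homo sapiens) for inhibition (a higher number here means a weaker inhibitor, a lower number a stronger inhibitor), compound 1 gives >= 40000 nM, a limit of the assay rather than a number (the limit of >= 40000 nM in this assay, at which 1 of the 2 values shown sits). Compound 2 `Cc1ccc(O)c(/C=N\NC(=O)c2oc3cccc(O)c3c2C)c1` gives 7350 nM in this assay. Among the compounds with values here, the single measured step, an at least 5.4-fold lower number from compound 1 to compound 2 (0.73 log units; beyond the scatter), comes from 2-hydroxy-5-methylphenyl in place of 2-fluorophenyl. Compound 3 `COc1ccccc1/C=N\NC(=O)c1oc2cccc(O)c2c1C` differs from compound 1 by methoxy in place of fluoro on an aromatic carbon. That measured step involves a larger change than this one, so only a small drop, within or near the scatter, is expected. Compound 3 is expected near 30000 nM (range 9000 nM to 60000 nM). The expected step is an at least 1.3-fold lower number from compound 1 to compound 3 (0.12 log units; that floor lies within the scatter).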

Compound 3, half-maximal inhibitory concentration: 32700 nM
Estimate against measurement, compound 3: 1.1-fold (0.04 log units) below; the range from low to high includes it.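

Methoxy in place of fluoro gives an at least 1.2-fold lower number from compound 1 to compound 3 (0.08 log units; that floor lies within the scatter) and that figure is only a floor, with the true size of the step unread since compound 1 stands at a limit: the limit of >= 40000 nM in this assay, at which 1 of the 3 values shown sits. A 2-methoxyphenyl group does not carry the lower number of the 2-hydroxy-5-methylphenyl group, as a 4.4-fold higher number from compound 2 to compound 3 (0.65 log units; beyond the scatter) shows. An oxygen on this aromatic carbon is therefore not enough by itself to reach the value of compound 2.

Still open, on these data alone, is whether the free hydroxy or the 5-methyl carries the step from compound 2 to compound 3. A plain 2-hydroxyphenyl group or an amine at this place would bear on that question.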